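The compounds below may be only part of what the source reports. "The series", "measured", "known", "first", "only" and "open" are said of these compounds alone.

Three compounds in the series already have numbers in a functional assay on K562 cells (Homo sapiens) for antiproliferative activity, read by CCK-8 assay, with a stated time of 72 h; a lower number here means a stronger inhibitor of growth, a higher number a weaker inhibitor of growth. Compound 1, `CCC1C(=O)N(C)c2cnc(-n3ccc4cc(C(N)=O)ccc43)nc2N1c1ccn(C)n1`, gives 31300 nM, the highest of the three. Compound 2, `CC[C@@H]1C(=O)N(C)c2cnc(-n3ccc4cc(C(=O)NC(C)C)ccc43)nc2N1C1CCCC1`, gives 786 nM, and compound 3, `CC[C@@H]1C(=O)N(C)c2cnc(-n3ccc4ccccc43)nc2N1C1CCCC1`, gives 6910 nM; between those two there is a single difference, hydrogen in place of isopropylcarbamoyl on an aromatic carbon, and it brings an 8.8-fold higher number from compound 2 to compound 3 (0.94 log units; beyond the scatter).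

Compound 4, `CCNC(=O)c1ccc2c(ccn2-c2ncc3c(n2)N(c2ccn(C)n2)C(CC)C(=O)N3C)c1`, differs from compound 1 in one place: ethyl in place of hydrogen on an amide-type nitrogen. Among the compounds with values here, no measured pair shows exactly this change. The nearest guide is the pair of compound 2 and compound 3, where the presence of an isopropylcarbamoyl group rather than hydrogen goes with a markedly lower number, which hints that an alkyl group on this amide-type nitrogen is at least tolerated. Compound 1 and compound 2 differ in several places at once, so their gap cannot be tied to the amide alone.

Compound 4 is therefore expected to come out somewhat lower than compound 1, with an estimated step of a 2.8-fold lower number from compound 1 to compound 4 (0.45 log units; beyond the scatter), giving an estimate of 11000 nM within a range from 3000 nM to 40000 nM in this assay.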

Compound 4, concentration for 50% growth inhibition: 12800 nM
Estimate against measurement, compound 4: 1.2-fold (0.07 log units) below, and the stated range covers the measured number.
By their numbers in this assay, from the lowest: compound 2; then compounds 3 and 4 (each within the scatter of the next); then compound 1.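

In this assay, replacing the amide hydrogen with ethyl, which turns carbamoyl into ethylcarbamoyl, gives a 2.4-fold lower number from compound 1 to compound 4 (0.39 log units; beyond the scatter). This is a direct reading of a change on this nitrogen alone, whereas the pair of compound 2 and compound 3 compared a whole isopropylcarbamoyl group with hydrogen on an aromatic carbon. On the core of compound 1, then, this nitrogen tolerates an ethyl group, with a modest gain in growth inhibition, though no measured evidence here accounts for the shift.

Still open, going by these compounds, is whether a longer chain such as butyl, or a chain ending in an amine or a carboxylic acid, would lower the number further or raise it again. Also open, on these data alone, is whether the same ethyl change would give a similar step on the core of compound 2.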